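The source may hold more compounds than are shown below. What is called first, only, known or untested is meant among the compounds shown, and "the series" means these compounds.

In a functional assay on NUGC-3 cells (Homo sapiens) for cytotoxicity, read by sulforhodamine B assay, with a stated time of 72 h (a higher number here means a weaker inhibitor of growth, a lower number a stronger inhibitor of growth), three compounds have been measured so far:

compound 1 `O=C(Nc1ccccc1O)C1CCc2ccccc2N1` gives 2680 nM;
compound 2 `O=C(Nc1cc(C(F)(F)F)cc(C(F)(F)F)c1)C1CCc2ccccc2N1` gives 8760 nM;
compound 3 `O=C(Nc1cc(C(F)(F)F)cc(C(F)(F)F)c1)C1CCc2ccccc2N1C(=O)c1cccc(Cl)c1` gives 560 nM.

Compound 2 and compound 3 share a core and differ in one place: (3-chlorophenyl)carbonyl in place of hydrogen on a nitrogen on an aromatic ring in a ring. That single change produced a 16-fold lower number from compound 2 to compound 3 (1.19 log units; beyond the scatter), a large step well beyond the scatter of this assay. Compound 1 carries a different aryl amide part; how its core differs from that of compound 2 is not broken down here, but its value lies between the other two and is beyond the scatter from each of them.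

Compound 4 `O=C(Nc1ccccc1O)C1CCc2ccccc2N1C(=O)c1cccc(Cl)c1` has not yet been measured in this assay. It arises from compound 1 by the same change, ((3-chlorophenyl)carbonyl in place of hydrogen on a nitrogen on an aromatic ring in a ring), and the place of the change is the same, word for word, in both pairs. Among the measured compounds shown here, the only precedent is the step from compound 2 to compound 3; compound 1 starts from a lower number, 2680 nM, so a step in the same direction is expected, though whether it reaches the same size is uncertain. Resting on a 16-fold lower number from compound 2 to compound 3 (1.19 log units; beyond the scatter), the step to compound 4 is estimated at an 11-fold lower number from compound 1 to compound 4 (1.03 log units; beyond the scatter). Compound 4 is therefore expected to give about 250 nM, most likely between 60 nM and 1000 nM.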

Compound 4, concentration for 50% growth inhibition: 11000 nM
Compound 4: middle estimate off by 44-fold (1.64 log units), on the low side; the measured number lies above the stated range.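

In this assay, among the compounds shown here, putting (3-chlorophenyl)carbonyl in place of hydrogen on the ring nitrogen of the core of compound 1 gave a 4.1-fold higher number from compound 1 to compound 4 (0.61 log units; beyond the scatter), the opposite direction to the only precedent. Set side by side, the two results do not agree: the same change on two cores in this assay, a 16-fold lower number (1.19 log units; beyond the scatter) from compound 2 to compound 3 and a 4.1-fold higher number (0.61 log units; beyond the scatter) from compound 1 to compound 4, 64-fold (1.81 log units) apart, beyond the scatter of two such steps. For the compounds shown here, this shows that, across these two pairs, the change cannot be carried from one core to another as a fixed step, since even its direction differs with the aryl amide part, but with only two pairs it does not show why, or which feature of that part matters, and it gives no rule for the series as a whole.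

The compounds shown leave open whether a single group on the aryl amide part decides the direction of the step, which a pair built on an unsubstituted phenyl amide, or on a methoxy group or an amine in place of the hydroxyl group, could test. They also leave open whether a different acyl group on the same nitrogen, such as acetyl or plain benzoyl, would split between the two cores in the same way.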